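A few compounds are considered here, and "the series" means these few. Any claim that something is new, unique, unknown or untested is made for them only; others in the source may bear on it.

- Compound 1 `COC1(c2nnc3c(Oc4cccc(Cl)c4C)cccn23)CCCCCC1`: < 1%, which is a limit and not a number
- Compound 2 `Cc1c(Cl)cccc1Oc1cccn2c(C3CCC(C)(O)CC3)nnc12`: 97%
- Compound 3 `Cc1c(Cl)cccc1Oc1cccn2c(C3CCCCCC3O)nnc12`: 43%

These values come from an ADME assay on microsomes from liver (Mus musculus) for metabolic stability, with a stated time of 10 min; a higher number here means that more of the compound is left, a lower number that less of the compound is left. Of the two true numbers, compound 3 has the lower, 43%. The next compound, compound 4 `Cc1c(Cl)cccc1Oc1cccn2c(C34CCC(O)(CC3)CC4)nnc12`, changes the same place: a group of 9 heavy atoms (8 carbon, 1 oxygen; 2 six-membered non-aromatic rings of carbon only) in place of a group of 8 heavy atoms (7 carbon, 1 oxygen; one seven-membered non-aromatic ring of carbon only), on an aromatic carbon. The closest guide is a number 54 percentage points lower from compound 2 to compound 3 (beyond the scatter), a large step showing how much this place can matter. Also large are a number at least 96 percentage points higher from compound 1 to compound 2 (beyond the scatter) and a number at least 42 percentage points higher from compound 1 to compound 3 (beyond the scatter). The entering six-membered rings are closer to the 4-hydroxy-4-methylcyclohexyl of compound 2, at 97%, than to the seven-membered ring that leaves, so a large rise is expected. The expected step is a number 42 percentage points higher from compound 3 to compound 4 (beyond the scatter). For compound 4 the estimate is 85%, with an expected range of 60% to 100%.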

Compound 4, percent of the compound remaining: 96%
For compound 4 the middle estimate is 11 percentage points below the measured one; the measured number falls inside the stated range.
By their numbers in this assay, from the lowest: compound 3; then compounds 4 and 2 (each within the scatter of the next). At a limit, below all of these: compound 1.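

In this assay, the group with two six-membered rings brings a large gain over 2-hydroxycycloheptyl, a number 53 percentage points higher from compound 3 to compound 4 (beyond the scatter), yet it sits level with 4-hydroxy-4-methylcyclohexyl, a number 1 percentage points lower from compound 2 to compound 4 (within the scatter), so two different carbon ring groups bearing a hydroxy group now give high values at this position. The remaining step, a number at least 95 percentage points higher from compound 1 to compound 4 (beyond the scatter), is only a bound. Compound 1 sits at a limit, which is not a number: the limit of < 1% in this assay, at which 1 of the 4 values shown sits.

Open, going by these compounds, is what an amine or a carboxylic acid would give in place of the hydroxy group on the two-ring group. Also open, on these data alone, is how a plain cyclohexyl, without oxygen, would compare.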